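A few compounds are considered here, and "the series" means these few. Any claim that something is new, unique, unknown or untested is made for them only; others in the source may bear on it.

Going by the values given here, in an ADME assay on Caco-2 cells (Homo sapiens) for permeability, read by LC-MS, in the apical to basolateral direction, with a stated time of 60 min, at pH 6.5 (on this read-out higher numbers stand for higher permeability and lower numbers for lower permeability), compound 2 (`CC(C)(C)C[C@@H](O)C(=O)N1[C@@H]2C[C@@H]2C[C@H]1C(=O)NCc1cc(Cl)ccc1-n1cnnn1`) gives 24 10^-6 cm/s, the higher of the two numbers so far, while compound 1 (`O=C(NCc1cc(Cl)ccc1-n1cnnn1)[C@@H]1C[C@H]2C[C@H]2N1C(=O)[C@H](O)CC1CC1`) gives 6.9 10^-6 cm/s. Compound 3 (`CC(C)(C)[C@@H](O)C(=O)N1[C@@H]2C[C@@H]2C[C@H]1C(=O)NCc1cc(Cl)ccc1-n1cnnn1`) differs from compound 2 by tert-butyl in place of neopentyl on a saturated chain carbon bound to a carbonyl carbon and an oxygen on a saturated carbon, with tert-butyl in place of neopentyl. Among the compounds with values here, the only measured step, a 3.5-fold higher number from compound 1 to compound 2 (0.54 log units; beyond the scatter), also exchanges a group on this chain and is modest. Within the data shown here, it gives the only guide to size, and no measured step shows this exact change. The expected step is a 1.7-fold lower number from compound 2 to compound 3 (0.23 log units; within the scatter), a small drop in this assay that stays within the scatter. For compound 3 the estimated value is 14 10^-6 cm/s, with an expected range of 6 10^-6 cm/s to 30 10^-6 cm/s.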

Compound 3, apparent permeability: 34 10^-6 cm/s
Estimate against measurement, compound 3: 2.4-fold (0.39 log units) below; the measured number lies above the stated range.
By their numbers in this assay, from the lowest: compound 1; then compounds 2 and 3 (each within the scatter of the next).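

In this assay, a 1.4-fold higher number from compound 2 to compound 3 (0.15 log units; within the scatter) comes with tert-butyl in place of neopentyl on this saturated chain carbon, so the two groups are not told apart here. a 4.9-fold higher number from compound 1 to compound 3 (0.69 log units; beyond the scatter) comes with tert-butyl in place of cyclopropylmethyl at the same place and, like the step to compound 2, separates compound 1 from the other two compounds. No supporting data explain these differences. Open, on these data alone, is whether a hydroxymethyl group, an amine or a carboxylic acid at this place would stay level with compound 2 and compound 3 or fall toward compound 1.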